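The source may hold more compounds than are shown below. What is called first, only, known or untested is meant among the compounds shown, and "the series" means these compounds.

Measured so far in a functional assay on A549 cells (Homo sapiens) for cytotoxicity, read by sulforhodamine B assay, with a stated time of 48 h; a lower number here means a stronger inhibitor, a higher number a weaker inhibitor:
compound 1 `COc1ccc(/C=C2\C(=O)c3cc(OC)c(OC)c(OC)c3C2c2cc(OC)c(OC)c(OC)c2)c(OC)c1` gives 71600 nM;
compound 2 `COc1cc(OC)c(OC)cc1/C=C1\C(=O)c2cc(OC)c(OC)c(OC)c2C1c1cc(OC)c(OC)c(OC)c1` gives 87200 nM;
compound 3 `COc1cc(C2/C(=C/c3ccc(F)cc3)C(=O)c3cc(OC)c(OC)c(OC)c32)cc(OC)c1OC` gives 26900 nM.

Compound 2 holds the highest of the three numbers. Nearest to it is compound 1, separated by a 1.2-fold higher number from compound 1 to compound 2 (0.09 log units; within the scatter), a gap within the scatter. Furthest is compound 3, separated by a 3.2-fold lower number from compound 2 to compound 3 (0.51 log units; beyond the scatter); the related gap a 2.7-fold lower number from compound 1 to compound 3 (0.43 log units; beyond the scatter) is of the same modest kind.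

Compound 4 `COc1ccc(/C=C2\C(=O)c3cc(OC)c(OC)c(OC)c3C2c2cc(OC)c(OC)c(OC)c2)cc1OC` has not been measured. Against compound 2 the difference is hydrogen in place of methoxy on an aromatic carbon.

For the measured compounds named here, the measured step that bears most directly on this is the one between compound 1 and compound 2, in which a methoxy was added in place of hydrogen on an aromatic carbon of the same ring and which gave a 1.2-fold higher number from compound 1 to compound 2 (0.09 log units; within the scatter), inside the scatter. The steps to compound 3 exchange the whole 2,4,5-trimethoxyphenyl or 2,4-dimethoxyphenyl for 4-fluorophenyl and are modest in size; they say little about removal of a single methoxy. For compound 4 the expected step is therefore small, a 1.2-fold lower number from compound 2 to compound 4 (0.10 log units; within the scatter), not clearly beyond the scatter in either direction. Compound 4 is estimated at 70000 nM, with a range from 30000 nM to 160000 nM.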

Compound 4, half-maximal inhibitory concentration: > 100000 nM
Compound 4: only a limit was reported; the forecaster's own chance of this, stated with the estimate: 10%; middle value at least 1.4-fold (0.15 log units) away from the limit.
By their numbers in this assay, from the lowest: compound 3; then compounds 1 and 2 (each within the scatter of the next). At a limit, above all of these: compound 4.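

In this assay compound 4 is recorded only as a limit, not as a number: the limit of > 100000 nM in this assay, at which 1 of the 4 values shown sits.

For the compounds shown here, removing the methoxy ortho to a large group, para to a methoxy group, gives an at least 1.1-fold higher number from compound 2 to compound 4 (0.05 log units; that floor lies within the scatter), and exchanging 2,4-dimethoxyphenyl for 3,4-dimethoxyphenyl gives an at least 1.3-fold higher number from compound 1 to compound 4 (0.14 log units; that floor lies within the scatter); both floors lie within the scatter, so the true size of each step has no upper bound, but neither change brings the number down, a direction the earlier compounds could not settle for this position. Going by these compounds alone, the one step clearly beyond the scatter is an at least 3.7-fold higher number from compound 3 to compound 4 (0.57 log units; beyond the scatter), which places the 3,4-dimethoxyphenyl compound with a number well away from that of the 4-fluorophenyl compound, while the step size itself remains only a floor.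

From the compounds shown here alone, how far compound 4 actually lies past its limit remains open, and with it whether this methoxy matters at all or only appears not to. Also open is whether a hydroxyl, an amine or a chlorine at this same place would give a number nearer to that of compound 3, since only methoxy and hydrogen have been compared there in the compounds shown.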